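The source may report more compounds than this note shows. Statements on the series, on what has been measured and on what is new or still open speak of the compounds shown alone.

In an assay on cells for inhibition of Tyrosinase (Homo sapiens), tested at 0.1 mM (on this read-out lower numbers stand for less inhibition and higher numbers for more inhibition at the one concentration tested (going by the name of the read-out)), compound 1 `O=C1/C(=C/c2ccc(O)cc2)Oc2cccc(O)c21` gives 71%, and compound 2 `O=C1/C(=C/c2ccc(O)cc2)Oc2cc(O)ccc21` gives 69%. On these two numbers compound 2 stands level with compound 1, the gap between them lying within the scatter. Compound 3 `CCc1ccc(/C=C2\Oc3cc(O)ccc3C2=O)cc1` differs from compound 2 by ethyl in place of hydroxy on an aromatic carbon. Going by the values given here, no measured pair shows this change, so its size is unknown; a fall beyond the scatter is expected, a step of a number 34 percentage points lower from compound 2 to compound 3 (beyond the scatter). Compound 3 is therefore expected at 35%, with an estimated range from 10% to 60%.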

Compound 3, a percentage reported as inhibition, at one concentration (the size of the read-out at that concentration, not a potency): 0%
Estimate against measurement, compound 3: 35 percentage points above, outside the stated range (below it).
By their numbers in this assay, from the lowest: compound 3; then compounds 2 and 1 (each within the scatter of the next).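

On this aromatic carbon, para to a large group, ethyl in place of hydroxy brings a number 69 percentage points lower from compound 2 to compound 3 (beyond the scatter) in this assay and leaves no inhibition to read at the one concentration tested. Going by these compounds alone, the earlier compounds showed no change at this position, so this pair is the first sign that the outcome depends strongly on the group placed here. The data shown give no cause for this fall. From the compounds shown here alone, it remains open whether a methoxy group, an amine or a methyl group here would retain any inhibition. Going by these compounds, it also remains open whether a single atom such as fluorine would behave more like hydroxy or like ethyl.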